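The compounds below may be only part of what the source reports. "The series", "measured", "known", "first", "only" and "open" are said of these compounds alone.

Measured so far, in an assay on HEK293 cells for displacement of a labelled ligand from 5-hydroxytryptamine receptor 6 (Homo sapiens), read by radioligand binding, with a stated time of 60 min, tested at 100 nM; a lower number here means less inhibition, a higher number more inhibition at the concentration tested (going by the name of the read-out): compound 1 `O=c1sc2cc(NS(=O)(=O)c3ccc4ccccc4c3)ccc2n1CCN1CCCC1` gives 0%; compound 2 `O=c1sc2cc(NS(=O)(=O)c3ccc4ccccc4c3)ccc2n1CCN1CCCCC1` gives 4%; compound 3 `CN(c1ccccc1)S(=O)(=O)c1ccc2c(c1)sc(=O)n2CCN1CCCC1` gives 10%.

Compound 1 and compound 2 share a core and differ only in the change (piperidin-1-yl in place of pyrrolidin-1-yl on a saturated chain carbon, two bonds along the chain from an aromatic nitrogen), which gave a number 4 percentage points higher from compound 1 to compound 2 (within the scatter). Compound 3 carries a different core; the difference between the two cores is not broken down here. Its number and those of compound 2 and compound 1 lie within the scatter of one another, so no ordering among the three is claimed.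

Compound 4 `CN(c1ccccc1)S(=O)(=O)c1ccc2c(c1)sc(=O)n2CCN1CCCCC1` is compound 3 with the same change, (piperidin-1-yl in place of pyrrolidin-1-yl on a saturated chain carbon, two bonds along the chain from an aromatic nitrogen), as that from compound 1 to compound 2. Because a number 4 percentage points higher from compound 1 to compound 2 (within the scatter) stayed within the scatter, a step of similar size is expected in this assay, namely a number 4 percentage points higher from compound 3 to compound 4 (within the scatter). Compound 4 is therefore estimated at 14%, expected to fall between 3% and 28%.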

Compound 4, a percentage reported as inhibition, at one concentration (the size of the read-out at that concentration, not a potency): 0%
Compound 4: the middle estimate sits 14 percentage points above what was measured; the measured number lies below the stated range.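

In this assay, piperidin-1-yl in place of pyrrolidin-1-yl gave a number 10 percentage points lower from compound 3 to compound 4 (within the scatter). Set beside the earlier step, the two do not separate: the same change on two cores in this assay, a number 4 percentage points higher (within the scatter) from compound 1 to compound 2 and a number 10 percentage points lower (within the scatter) from compound 3 to compound 4, 14 percentage points apart, within the scatter of two such steps. This gives no sign that the change behaves differently on the two cores, but it does not show that the change has any effect on either core, or that its effect is the same on both.

Open, on these data alone, is whether another amine in place of piperidin-1-yl, such as morpholin-4-yl or dimethylamino, or a longer chain, such as 3-(piperidin-1-yl)propyl, would give a number beyond the scatter in this assay. Also open, as far as these compounds go, is how the change behaves on a core with clearly higher inhibition.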